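Cyclopropyl Ketone to Methylamide on a Bicyclic Amine Core

The source may hold more compounds than are shown below. What is called first, only, known or untested is meant among the compounds shown, and "the series" means these compounds.

Of the compounds shown here, two have been measured in an assay on SHEP1 cells for displacement of a labelled ligand from Neuronal acetylcholine receptor; alpha4/beta2 (Homo sapiens), read by scintillation counting, with a stated time of 2 h; on this read-out lower numbers stand for stronger inhibition and higher numbers for weaker inhibition. Compound 1 `C[C@@H]1C[C@H]1C(=O)N1CC2CNCC2C1` gives 4 nM in this assay, while compound 2 `O=C(C1CC1)[C@H]1C[C@@H]2CNC[C@@H](C2)C1` gives 43 nM. Compound 2 therefore carries the higher of the two numbers, and its gap to compound 1 lies beyond the usual scatter of this assay; the two share no single-point relationship, so their values can only be read side by side.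

The step from compound 2 leads to compound 3 `CNC(=O)[C@H]1C[C@@H]2CNC[C@@H](C2)C1`, which is not yet measured in this assay. The change is methylamino in place of cyclopropyl on a carbonyl carbon. No comparable step between measured compounds is available, so the direction of the effect rests on general expectation rather than on a shown precedent. Compound 3 is expected to land a little weaker than compound 2, with a step of about a 1.9-fold higher number from compound 2 to compound 3 (0.27 log units; within the scatter) in this assay. The estimate for compound 3 is 80 nM, within a range from 15 nM to 400 nM.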

Compound 3, inhibition constant: 1.9 nM
The estimate for compound 3 lay 42-fold (1.62 log units) above the measured number, and the stated range ends above it.
By their numbers in this assay, from the lowest: compound 3; then compound 1; then compound 2.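

In this assay, within the data shown here, methylamino in place of cyclopropyl on a carbonyl carbon gives a 23-fold lower number from compound 2 to compound 3 (1.35 log units; beyond the scatter), a large step that shows, as no earlier pair could, that the read-out responds strongly to the group at this place. The change swaps a ketone for an amide, removes the three-membered ring and brings in a nitrogen and a hydrogen-bond donor all at once, so this single pair cannot separate these differences. Nothing available accounts for the size of the step.

The compounds shown leave open whether the amide hydrogen is needed, which dimethylamino on the same carbonyl carbon would test. They also leave open how a plain amino group or the longer ethylamino chain would compare with methylamino.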